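From 4-chlorophenyl to 3-iodophenyl on a shared core

A few compounds are considered here, and "the series" means these few. Any claim that something is new, unique, unknown or untested is made for them only; others in the source may bear on it.

Of the compounds shown here, three sharing one core have been measured in a functional assay on HepG2 cells (Homo sapiens) for inhibition, read by MTT assay; a lower number here means a stronger inhibitor, a higher number a weaker inhibitor. There compound 1 (`COc1cc2ncnc(Nc3ccc(NC(=O)c4ccccc4C)cc3)c2cc1OC`) gives 15000 nM, compound 2 (`COc1cc2ncnc(Nc3ccc(NC(=O)c4ccc(C)cc4)cc3)c2cc1OC`) gives 25000 nM and compound 3 (`COc1cc2ncnc(Nc3ccc(NC(=O)c4ccc(Cl)cc4)cc3)c2cc1OC`) gives 28000 nM. Compound 3 thus stands level with the other two, as all three numbers lie within the scatter of one another.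

Compound 4 (`COc1cc2ncnc(Nc3ccc(NC(=O)c4cccc(I)c4)cc3)c2cc1OC`) has not been measured yet. Its difference from compound 3 is 3-iodophenyl in place of 4-chlorophenyl on a carbonyl carbon. In short, 3-iodophenyl comes in place of 4-chlorophenyl on a carbonyl carbon.

Among the measured compounds shown here, three measured steps bear on this change: a 1.7-fold higher number from compound 1 to compound 2 (0.22 log units; within the scatter), a 1.9-fold higher number from compound 1 to compound 3 (0.27 log units; within the scatter) and a 1.1-fold higher number from compound 2 to compound 3 (0.05 log units; within the scatter). For the measured compounds named here, each of these swaps on the same carbonyl carbon stayed small, but none of the measured compounds carries 3-iodophenyl, so the guide is only indirect. In this assay, no shift beyond the scatter is therefore expected. The expected step is a 1.3-fold lower number from compound 3 to compound 4 (0.10 log units; within the scatter). For compound 4 the estimated value is 22000 nM, with an expected range from 10000 nM to 45000 nM.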

Compound 4, half-maximal inhibitory concentration: 28000 nM
Beside the measured number, compound 4's estimate is 1.3-fold (0.10 log units) below it, and the stated range covers the measured number.
By their numbers in this assay, from the lowest: compounds 1, 2, 3 and 4 (each within the scatter of the next).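

In this assay this one swap changes both the halogen and its place in the name of the ring, yet it gives no change at the digits printed from compound 3 to compound 4 (within the scatter). Against the two methyl compounds, the same group gives a 1.1-fold higher number from compound 2 to compound 4 (0.05 log units; within the scatter) and a 1.9-fold higher number from compound 1 to compound 4 (0.27 log units; within the scatter), so all four substituted phenyl groups on this carbonyl carbon now lie within the scatter of one another, and 3-iodophenyl adds a new halogen and a new ring position without separating from the rest. Nothing available here explains why these numbers stay together.

Because both features changed at once, the effect of each remains unresolved, and 3-chlorophenyl would help separate them. Whether this position responds at all also remains open, as every group shown is a substituted phenyl, leaving a phenyl carrying an amine or a carboxylic acid untested here.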